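The compounds below may be only part of what the source reports. "The series", "measured", "known", "first", "only" and "open" are said of these compounds alone.

Compound 1 `COc1nc(N)nc2c1c(-c1ccco1)cn2[C@@H]1O[C@H](CO)[C@@H](O)[C@H]1O`: > 20000 nM
Compound 2 `COc1nc(N)nc2c1c(-c1ccsc1)cn2[C@@H]1O[C@H](CO)[C@@H](O)[C@H]1O`: > 20000 nM

Both compounds were tested in a functional assay on HCT-116 cells (Homo sapiens), read by MTT assay, with a stated time of 72 h; a lower number here means a stronger inhibitor, a higher number a weaker inhibitor. Compound 1 gives > 20000 nM, which is a limit of the assay and not a number. Compound 2 also gives > 20000 nM, again a limit and not a number. Compound 2 therefore stands with compound 1 at the limit of > 20000 nM in this assay, at which 2 of the 2 values shown sit.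

The next change gives compound 3 `COc1nc(N)nc2c1c(-c1ccccc1)cn2[C@@H]1O[C@H](CO)[C@@H](O)[C@H]1O`, with phenyl in place of thiophen-3-yl on an aromatic carbon.

Among the measured compounds shown here, only one measured step bears on this change, a swap at the same place: a step that the two limits leave unreadable from compound 1 to compound 2. That step has no readable size to carry over. Neither of the two aryl swaps' starting compounds gives a number, so no clear move in either direction is expected in this assay, and compound 3 will most likely also stop at the limit. The step expected is a step that the limit leaves unreadable from compound 2 to compound 3. For compound 3 the estimated value is 25000 nM, with an expected range from 12000 nM to 50000 nM.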

Compound 3, half-maximal inhibitory concentration: > 20000 nM
Compound 3 gave a limit, no number; the forecaster's own chance of this, stated with the estimate: 85%; the middle value does not contradict the limit.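

Compound 3, like compound 1 and compound 2, gives only a limit and no number in this assay, so no step among these three compounds can be read: the limit of > 20000 nM in this assay, at which 3 of the 3 values shown sit.

The compounds shown leave open how the three actually compare with one another.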